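Mirror-image pair: expected lipophilicity of compound 4

The source may report more compounds than this note shows. Statements on the series, on what has been measured and on what is new or still open speak of the compounds shown alone.

Three compounds have been measured in a physicochemical assay for lipophilicity; a higher number here means a more lipophilic compound, a lower number a more polar compound:

- compound 1, `CNCC(=O)Nc1ccc(-c2nc(CS(C)(=O)=O)cc([C@]34CCOC[C@H]3C4)n2)cc1`, gives 3.1
- compound 2, `CC(C)(c1cc([C@@]23CCOC[C@@H]2C3)nc(-c2cccc(O)c2)n1)S(C)(=O)=O`, gives 4.8
- compound 3, `CCNC(=O)Nc1ccc(-c2nccc([C@@]34CCOC[C@@H]3C4)n2)cc1`, gives 3.9

Among these three numbers compound 3 stands second highest. Its nearest neighbour is compound 1, which lies lower by a margin beyond the usual scatter, and its furthest is compound 2, which lies higher, again beyond the scatter. Going by the values given here, no pair of these measured compounds differs in only one place, so no single measured step is available for comparison.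

The unmeasured compound 4, `CCNC(=O)Nc1ccc(-c2nccc([C@]34CCOC[C@H]3C4)n2)cc1`, is related to compound 3 as follows: the two compounds have the same atoms and bonds and differ only in configuration as drawn: 2 of 2 stereo elements differ (all stereocentres are inverted: mirror images); a stereocentre at a saturated ring carbon is drawn S in compound 3 and R in compound 4; a stereocentre at a saturated ring carbon is drawn R in compound 3 and S in compound 4. Two mirror-image compounds share every atom and bond, and a partition between two liquid phases does not distinguish them, so no step beyond the scatter is expected in this assay from compound 3 to compound 4, in either direction. Compound 4 is therefore expected to give 3.9, within 3.6 to 4.2, an expected step of no change at the digits printed from compound 3 to compound 4 (within the scatter).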

Compound 4, partition coefficient: 3.9
Compound 4: the middle estimate sits on the measured number at the digits printed; the range from low to high includes it.
By their numbers in this assay, from the lowest: compound 1; then compounds 3 and 4 (each within the scatter of the next); then compound 2.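

Going by these compounds alone, this is the first pair in the set that differs in only one respect, so a gap can be tied to a single change, which the wide gaps among compounds 1, 2 and 3 did not allow. In this assay, inverting both stereocentres at the saturated ring carbons gives no change at the digits printed from compound 3 to compound 4 (within the scatter), so at this position the drawn configuration of the mirror-image pair leaves the reading undisturbed. This result rests on one structural fact: the fact that compounds 3 and 4 differ only in the configuration as drawn.

Inverting only one of the two stereocentres would give a compound that is not a mirror image, and no such compound appears here. As far as these compounds go, what a change of group rather than of configuration would do also remains open, for example a carboxylic acid or a longer chain in place of the ethyl group.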